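Chain Extension at the Ring Nitrogen of a Bronchodilator Scaffold

The source may report more compounds than this note shows. Statements on the series, on what has been measured and on what is new or still open speak of the compounds shown alone.

Measured compounds:
compound 1, `Cn1nc(-c2cccnc2)c2ccccc2c1=O`, 11500 nM
compound 2, `CC(=O)Cn1nc(-c2cccnc2)c2ccccc2c1=O`, 40700 nM

Within the data shown here, in a functional assay (trachea) with Cavia porcellus as the target (on this read-out higher numbers stand for weaker inhibition and lower numbers for stronger inhibition), compound 2 stands at the highest of the two numbers; its nearest neighbour is compound 1, and the only measured step is a 3.5-fold higher number from compound 1 to compound 2 (0.55 log units; beyond the scatter). Compound 3, `O=C(O)CCCn1nc(-c2cccnc2)c2ccccc2c1=O`, differs from compound 2 by 2-carboxyethyl in place of acetyl on a saturated chain carbon bound to an aromatic nitrogen. Among the measured compounds shown here, the one measured step bears on this change only in part: it shows that adding an acetyl on a saturated chain carbon bound to an aromatic nitrogen made the number higher, but nothing in the data shows what a 2-carboxyethyl does in the same place. The chain is lengthened and a hydrogen-bond donor appears, and no comparison measures either. Compound 3 is therefore expected to stay near compound 2 in this assay, with a step of a 1.4-fold lower number from compound 2 to compound 3 (0.13 log units; within the scatter) that is not expected to go beyond the scatter. The estimate for compound 3 is 30000 nM, within a range from 8000 nM to 110000 nM.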

Compound 3, half-maximal inhibitory concentration: > 100000 nM
Compound 3: a limit, no number; the forecaster's own chance of this, stated with the estimate: 25%; middle value at least 3.3-fold (0.52 log units) from the limit.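

In this assay compound 3 is a limit of the assay and not a number: the limit of > 100000 nM in this assay, at which 1 of the 3 values shown sits. Even so, the step can be read in one direction: 2-carboxyethyl in place of acetyl on a saturated chain carbon bound to an aromatic nitrogen gives an at least 2.4-fold higher number from compound 2 to compound 3 (0.39 log units; beyond the scatter), so this place does respond to a change of group once a substituent already stands there. Against the hydrogen of compound 1 the change is larger, with an at least 8.6-fold higher number from compound 1 to compound 3 (0.93 log units; beyond the scatter), and both substituents shown so far move the number the same way.

The compounds shown do not separate the longer chain from the carboxylic acid at its end. Going by these compounds, what a methyl ester, an amide or a plain alkyl chain would give at this place remains open, as does how far above the limit compound 3 lies.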